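Does a fluorine bring compound 4 closer to compound 3?

The compounds below may be only part of what the source reports. "The series", "measured", "known", "first", "only" and "open" are said of these compounds alone.

Compound 1 `COc1ccccc1-c1ccc2ncn(-c3cc(OC)c(OC)c(OC)c3)c2c1` at 1750 nM
Compound 2 `COc1cc(-n2cnc3ccc(-c4ccc(C(C)=O)cc4)cc32)cc(OC)c1OC` at 1540 nM
Compound 3 `COc1cc(-n2cnc3ccc(-c4ccc(C)cc4F)cc32)cc(OC)c1OC` at 56 nM

In a functional assay on MCF7 cells (Homo sapiens) for antiproliferative activity, read by MTT assay, with a stated time of 72 h (a higher number here means a weaker inhibitor, a lower number a stronger inhibitor), compound 2 stands at 1540 nM and sits level with compound 1, as a 1.1-fold lower number from compound 1 to compound 2 (0.06 log units; within the scatter) shows. Compound 4 `COc1ccc(-c2ccc3ncn(-c4cc(OC)c(OC)c(OC)c4)c3c2)cc1F` is still unmeasured. It carries 3-fluoro-4-methoxyphenyl in place of 4-acetylphenyl on an aromatic carbon with the shared core unchanged. Among the compounds with values here, two large steps bear on this swap: a 28-fold lower number from compound 2 to compound 3 (1.44 log units; beyond the scatter) and a 31-fold lower number from compound 1 to compound 3 (1.49 log units; beyond the scatter) both end at the only other fluorine-bearing compound. Compound 4 shares its fluorine with compound 3 but its methoxy with compound 1, so the evidence is thin. The expected result is a 6.2-fold lower number from compound 2 to compound 4 (0.79 log units; beyond the scatter) as a clear fall in the number, yet smaller than those two. Compound 4 is estimated at 250 nM with a range from 50 nM to 1300 nM as its plausible span.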

Compound 4, half-maximal inhibitory concentration: 520 nM
The estimate for compound 4 lay 2.1-fold (0.32 log units) below the measured number; the range from low to high includes it.
By their numbers in this assay, from the lowest: compound 3; then compound 4; then compounds 2 and 1 (each within the scatter of the next).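

In this assay the 3-fluoro-4-methoxyphenyl group brings a real gain at this position, with a 3.0-fold lower number from compound 2 to compound 4 (0.47 log units; beyond the scatter) and a 3.4-fold lower number from compound 1 to compound 4 (0.53 log units; beyond the scatter) placing compound 4 clear of the two weakest compounds. Carrying a fluorine is still not enough to match 2-fluoro-4-methylphenyl, as a 9.3-fold higher number from compound 3 to compound 4 (0.97 log units; beyond the scatter) shows. Nothing measured here explains these gaps. Whether the fluorine or the methoxy in compound 4 accounts for its gain stays open. So does how an amine or a carboxylic acid on this phenyl ring would fare.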